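A few compounds are considered here, and "the series" means these few. Any claim that something is new, unique, unknown or untested is made for them only; others in the source may bear on it.

Of the compounds shown here, three have been measured in a functional assay on cells for positive allosteric modulation of metabotropic glutamate receptor 2 (Homo sapiens), read by fluorescence and calcium flux, with a stated time of 30 min; on this read-out lower numbers stand for an effect already at smaller amounts and higher numbers for an effect only at larger amounts of compound. Compound 1, `Brc1ccc(Cn2nnc3c(Br)cccc32)cn1`, gives 210 nM. Compound 2, `Clc1ccc(Cn2nnc3c(Br)cccc32)cn1`, gives 290 nM in this assay. These two share a core and differ in a single group, the change being (chloro in place of bromo on an aromatic carbon); it brought a 1.4-fold higher number from compound 1 to compound 2 (0.14 log units; within the scatter). Compound 3, `Brc1cc(Br)c2nnn(CC3CC3)c2c1`, is built on a different core, and the difference between the two cores is not broken down here. In this assay compound 3 gives 50 nM, the lowest of the three numbers, with steps to compound 1 and to compound 2 that lie beyond the scatter.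

Compound 4, `Clc1cc(Br)c2nnn(CC3CC3)c2c1`, has not yet been measured. It relates to compound 3 as compound 2 relates to compound 1, through (chloro in place of bromo on an aromatic carbon). This change occurs in two pairs among the compounds shown. The two changes are the same kind of change rather than the same: in compound 1 the bromo sits on a six-membered aromatic ring with 1 nitrogen, next to the ring nitrogen and para to a large group, whereas in compound 3 it sits on a six-membered aromatic ring of carbon only, part of a fused system of two rings, meta to a bromo group, meta to a fused ring and para to a fused ring.

Going by the values given here, the only guide is the measured step of a 1.4-fold higher number from compound 1 to compound 2 (0.14 log units; within the scatter), which stayed within the scatter. On that basis the expected step is a 1.3-fold higher number from compound 3 to compound 4 (0.11 log units; within the scatter). Compound 4 is estimated to give about 65 nM, expected to fall between 30 nM and 140 nM.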

Compound 4, half-maximal effective concentration: 60 nM
Beside the measured number, compound 4's estimate is 1.1-fold (0.03 log units) above it; the measured number falls inside the stated range.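

Replacing bromo with chloro on the core of compound 3 gave a 1.2-fold higher number from compound 3 to compound 4 (0.08 log units; within the scatter) in this assay, so here too the swap produced no change that can be told apart from the ordinary spread of repeated measurements. Set side by side, the two results agree: the same change on two cores in this assay, a 1.4-fold higher number (0.14 log units; within the scatter) from compound 1 to compound 2 and a 1.2-fold higher number (0.08 log units; within the scatter) from compound 3 to compound 4, 1.2-fold (0.06 log units) apart, within the scatter of two such steps. This shows that, in the two pairs available, the swap had an equally small effect on the read-out on both cores, even though it was made at a different place on each; it does not show that the same would hold on a third core or at another place on these two, and it does not explain why the effect was so small.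

As far as these compounds go, all four compounds carry a bromo or a chloro group at the place that was changed, so it remains open whether a fluoro group, a methoxy group or an amine there would leave the number as little changed as chloro did. Also open is which part of the difference between the core of compound 1 and the core of compound 3 accounts for the gap in their numbers, since those two compounds differ in more than one place.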